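A pentyloxy analogue of a tolerated cyclopropyl nucleoside

The source may report more compounds than this note shows. Statements on the series, on what has been measured and on what is new or still open speak of the compounds shown alone.

Measured compounds:
compound 1, `CCCSc1nc(N)nc2c1ncn2/C=C1/CC1(CO)CO`: > 20000 nM
compound 2, `CC(C)Nc1nc(N)nc2c1ncn2/C=C1/CC1(CO)CO`: "not determined" (no result reported)
compound 3, `CC(C)CNc1nc(N)nc2c1ncn2/C=C1/CC1(CO)CO`: "not determined" (no result reported)

In an ADME assay on MOLT-3 cells (Homo sapiens) for cytotoxicity, with a stated time of 7 days (a higher number here means that more compound is tolerated, a lower number that less compound is tolerated), compound 1 gives only an assay limit, > 20000 nM. Compound 2 gives "not determined" (no result reported) and compound 3 gives "not determined" (no result reported) in this assay, so no single number stands beside compound 1. Compound 1 therefore sits at the limit of > 20000 nM in this assay, at which 1 of the 3 values shown sits, with nothing to rank it against.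

Compound 4, `CCCCCOc1nc(N)nc2c1ncn2/C=C1/CC1(CO)CO`, differs from compound 1 by pentyloxy in place of propylsulfanyl on an aromatic carbon. Within the data shown here, no measured pair with this change exists. Since compound 1 lies at the limit, the change is expected to bring no step beyond the scatter in this assay, and the step that the limit leaves unreadable from compound 1 to compound 4 is an expectation only. Compound 4 is estimated at 25000 nM, between 10000 nM and 60000 nM, most likely reported again as a limit.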

Compound 4, half-maximal cytotoxic concentration: > 20000 nM
Compound 4: a limit, no number (the forecaster's own chance of this, stated with the estimate: 80%); the middle value is on the limit's open side.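

Compound 1 and compound 4 both give only a limit, not a number, in this assay, so no step between them can be read: the limit of > 20000 nM in this assay, at which 2 of the 4 values shown sit.

The compounds shown leave open whether pentyloxy and propylsulfanyl differ at all in this read-out.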